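From Methyl to Isopropyl at a Half-Life Limit

The compounds below may be only part of what the source reports. "The series", "measured", "known", "first", "only" and "open" are said of these compounds alone.

Compound 1 (`CCN(CC)CCCCCN/C(C)=N\c1ccnc2cc(Cl)ccc12`) gives > 1 h as a limit
Compound 2 (`C/C(=N/c1ccnc2cc(Cl)ccc12)NCCCCN1CCCCC1`) gives > 1 h as a limit

In an ADME assay (liver, Mus musculus) for metabolic stability, read by LC-MS, using microsomes, tested at 1 uM (a lower number here means that the compound disappears faster, a higher number that the compound lasts longer), compound 2 stands at > 1 h, which is a limit and not a number. The two measured compounds share one reading, namely (the limit of > 1 h in this assay, at which 2 of the 2 values shown sit). Compound 3 (`CC(C)/C(=N/c1ccnc2cc(Cl)ccc12)NCCCCN1CCCCC1`) carries isopropyl in place of methyl on a carbon with a double bond to nitrogen. Among the compounds with values here, only one measured step exists, a step that the two limits leave unreadable from compound 1 to compound 2, and it involves a different change. It therefore offers no size to carry over to this one. With no measured guide, no shift beyond the scatter is expected in this assay, and no direction can be favoured. The expected step is a step that the limit leaves unreadable from compound 2 to compound 3. For compound 3 the estimated half-life is 1.5 h, with an expected range from 0.7 h to 4 h.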

Compound 3, half-life: 0.517 h
The estimate for compound 3 lay 2.9-fold (0.46 log units) above the measured number; the whole stated range lies above it.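

In this assay, isopropyl in place of methyl on a carbon with a double bond to nitrogen gives an at least 1.9-fold lower number from compound 2 to compound 3 (0.28 log units; that floor lies within the scatter). Compound 3, at 0.517 h, is the only one of the three compounds with a number rather than a limit, which makes this the first change shown whose direction can be read. The floor of the step nevertheless stays within the scatter. The earlier pair offered no such reading, and the step between them cannot be read: the limit of > 1 h in this assay, at which 2 of the 3 values shown sit.

Going by these compounds, compound 2 gives > 1 h, which is a limit, and the full size of the step therefore stays open. Also open, on these data alone, is whether ethyl or cyclopropyl on this carbon would read closer to compound 2 or to compound 3, and whether isopropyl would act alike with the diethylamino chain of compound 1.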